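The compounds below may be only part of what the source reports. "The series", "measured", "known", "first", "only" and "open" are said of these compounds alone.

Measured so far in a physicochemical assay for lipophilicity, at pH 7.4; on this read-out higher numbers stand for higher lipophilicity and lower numbers for lower lipophilicity:

- compound 1 `CNC(=O)c1cc(N)c(Nc2ccc(C#N)cc2)cc1Oc1c(C)cc(CCC#N)cc1C`: 2.65
- compound 2 `Cc1cc(CCC#N)cc(C)c1Oc1cc(Nc2ccc(C#N)cc2)c(N)cc1C(F)(F)F`: > 5

Compound 2 stands at the limit of > 5 in this assay, at which 1 of the 2 values shown sits, so its > 5 is a limit and not a number.

Compound 3 `COC(=O)c1cc(N)c(Nc2ccc(C#N)cc2)cc1Oc1c(C)cc(CCC#N)cc1C` is the next to consider. It has methoxycarbonyl in place of trifluoromethyl on an aromatic carbon, para to a (4-cyanophenyl)amino group: methoxycarbonyl in place of trifluoromethyl on an aromatic carbon.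

Going by the values given here, only one measured step bears on this change. It is a number at least 2.35 log units higher from compound 1 to compound 2 (beyond the scatter), a large step beyond the scatter, made when trifluoromethyl took the place of methylcarbamoyl on that same aromatic carbon. The new change runs the opposite way, removing trifluoromethyl and bringing back a group with a carbonyl. A large fall in this assay is therefore expected, and the guide is compound 1 at 2.65, which carries the closest group measured so far. Its exact size cannot be fixed, since one end of it is only a limit. The expected change is a number at least 1.50 log units lower from compound 2 to compound 3 (beyond the scatter). For compound 3 the estimated value is 3.5, with an expected range of 2.9 to 4.2.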

Compound 3, partition coefficient: 4.15
Compound 3: middle estimate off by 0.65 log units, on the low side; the range from low to high includes it.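

In this assay, changing only methylamino to methoxy on the carbonyl carbon gives a number 1.50 log units higher from compound 1 to compound 3 (beyond the scatter), so two groups that both carry a carbonyl at this position can still lie far apart. Putting methoxycarbonyl in place of trifluoromethyl gives a number at least 0.85 log units lower from compound 2 to compound 3 (beyond the scatter), which places methoxycarbonyl between methylcarbamoyl and trifluoromethyl in these three compounds, a middle position that compound 1 and compound 2 alone could not reveal. That second step gives only the smallest possible size of the gap, not its true size, because the value for compound 2 is a limit and not a number: the limit of > 5 in this assay, at which 1 of the 3 values shown sits.

The compounds shown leave open where a carboxylic acid, an unsubstituted amide or an ethyl ester would fall at this position, and so whether the order seen here extends beyond these three groups. Going by these compounds, it also remains open whether the same exchange of methylamino for methoxy would give a step of similar size if other parts of the shared core were changed.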